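The source may report more compounds than this note shows. Statements on the series, on what has been measured and on what is new or still open speak of the compounds shown alone.

Working notes on the series. Compound 1 `C=CCn1c(=O)/c(=C\c2cc(F)ccc2C)[nH]c(=O)/c1=C\c1ccccc1OC` gives 2600 nM in a functional assay on HL-60 cells (Homo sapiens) for cytotoxicity, read by CCK-8 assay, with a stated time of 72 h; on this read-out lower numbers stand for stronger inhibition and higher numbers for weaker inhibition. For the measured compounds named here, compound 2 `C=CCn1c(=O)/c(=C\c2cccc(Cl)c2)[nH]c(=O)/c1=C\c1ccccc1OC` gives 4500 nM in this assay, the highest of the two numbers so far; its nearest neighbour is compound 1, and the change from compound 1 to compound 2 gave a 1.7-fold higher number from compound 1 to compound 2 (0.24 log units; within the scatter), a step that stays within the scatter. Compound 3 `C=CCn1c(=O)/c(=C\c2ccccc2C(F)(F)F)[nH]c(=O)/c1=C\c1ccccc1OC` is not yet measured. Its change from compound 2 is 2-(trifluoromethyl)phenyl in place of 3-chlorophenyl on a double-bonded chain carbon bound to an aromatic carbon. Going by the values given here, only one measured step bears on this, the exchange of one aryl group for another at the same place, and that step a 1.7-fold higher number from compound 1 to compound 2 (0.24 log units; within the scatter) stayed within the scatter, so no step beyond the scatter is expected in this assay here either. The number for compound 3 in this assay is therefore estimated at 3500 nM, with a range of 1200 nM to 10000 nM, which amounts to an expected step of a 1.3-fold lower number from compound 2 to compound 3 (0.11 log units; within the scatter).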

Compound 3, half-maximal inhibitory concentration: 4600 nM
Estimate against measurement, compound 3: 1.3-fold (0.12 log units) below; measured number inside the range.
By their numbers in this assay, from the lowest: compounds 1, 2 and 3 (each within the scatter of the next).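

In this assay the place on a double-bonded chain carbon bound to an aromatic carbon now carries a third aryl group, and a 1.0-fold higher number from compound 2 to compound 3 (0.01 log units; within the scatter) and a 1.8-fold higher number from compound 1 to compound 3 (0.25 log units; within the scatter) both stay within the scatter. For the compounds shown here, with 2-(trifluoromethyl)phenyl, at 10 heavy atoms, entering for 3-chlorophenyl, at 7, a change in the size of the group by that count also produces no step beyond the scatter, which the single earlier step could not show. Nothing at hand offers an explanation for this flat result.

All three aryl groups carry halogen, so the compounds shown leave open whether a phenyl ring bearing an amine or a carboxylic acid at this place would give a step beyond the scatter. Going by these compounds, whether a longer chain in place of the aryl group would do so also remains open.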